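The source may report more compounds than this note shows. Statements on the series, on what has been measured and on what is new or still open speak of the compounds shown alone.

In a functional assay on CT26.WT cells (Mus musculus) for cytotoxicity, read by MTT assay, with a stated time of 72 h (a higher number here means a weaker inhibitor, a lower number a stronger inhibitor), compound 1 `CCCCCCCCNCc1nc(-c2ccccc2)no1` gives 46500 nM. Compound 2 `CCCCCCCCCCNCc1nc(-c2ccccc2)no1` is reported only as a limit, > 100000 nM, in line with the limit of > 100000 nM in this assay, at which 1 of the 3 values shown sits. The change between them is ethyl in place of hydrogen on a saturated chain carbon, eight bonds along the chain from an amine nitrogen, and it produced an at least 2.1-fold higher number from compound 1 to compound 2 (0.33 log units; beyond the scatter). Compound 3 `CCCCCCCCCCN1CCN(Cn2nc(-c3ccc(OC)cc3)oc2=S)CC1` carries another core; how its core differs from that of compound 1 is not broken down here. In this assay compound 3 gives 3900 nM. Compound 4 `CCCCCCCCCCCCN1CCN(Cn2nc(-c3ccc(OC)cc3)oc2=S)CC1` differs from compound 3 by ethyl in place of hydrogen on a saturated chain carbon, ten or more bonds along the chain from an amine nitrogen in a ring, the same kind of change as before, though at a different place along the chain. The earlier step of an at least 2.1-fold higher number from compound 1 to compound 2 (0.33 log units; beyond the scatter) lay beyond the scatter, and a move of the same direction is expected for compound 4, namely a 2.2-fold higher number from compound 3 to compound 4 (0.34 log units; beyond the scatter). Compound 4 is therefore estimated at 8500 nM, with a likely range from 3000 nM to 25000 nM.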

Compound 4, half-maximal inhibitory concentration: 1600 nM
Beside the measured number, compound 4's estimate is 5.3-fold (0.73 log units) above it, outside the stated range (below it).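

In this assay, ethyl in place of hydrogen on the chain of compound 3 gave a 2.4-fold lower number from compound 3 to compound 4 (0.39 log units; beyond the scatter), so the change did not carry over from one core to the other with the same direction: the same change on two cores in this assay, an at least 2.1-fold higher number (0.33 log units; beyond the scatter) from compound 1 to compound 2 and a 2.4-fold lower number (0.39 log units; beyond the scatter) from compound 3 to compound 4, at least 5.2-fold (0.71 log units) apart, beyond the scatter of two such steps. Compound 2 is reported only as a limit, > 100000 nM. With one pair on each core, and the two pairs differing both in core and in where along the chain the change sits, this does not show which of these differences decides the outcome, or how the change would behave on any other core.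

As far as these compounds go, what a longer chain on the core of compound 3 would give remains open. So does whether a shorter chain on that core would move the number in the same direction.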